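This account rests on a few compounds, and the source may have more. Where it says the series, first, only, none or still open, it means among the compounds named here.

Measured so far in a functional assay on SF-268 cells (Homo sapiens) for cytotoxicity, read by MTT assay, with a stated time of 3 days; on this read-out lower numbers stand for stronger inhibition and higher numbers for weaker inhibition
- compound 1 `N#Cc1c(Cl)nc(SCc2nc3ccccc3[nH]2)nc1-c1ccccc1` at 3.2 nM
- compound 2 `CCNc1nc(SCc2nc3ccccc3[nH]2)nc(-c2ccccc2)c1C#N` at 7.35 nM
- compound 3 `N#Cc1c(NNC(N)=S)nc(SCc2nc3ccccc3[nH]2)nc1-c1ccccc1` at 3.37 nM

Compound 3 stands within the scatter of compound 1 (a 1.1-fold higher number from compound 1 to compound 3 (0.02 log units; within the scatter)) and at a lower number than compound 2 (a 2.2-fold lower number from compound 2 to compound 3 (0.34 log units; beyond the scatter)). Still unmeasured, compound 4 `N#Cc1c(NC(N)=O)nc(SCc2nc3ccccc3[nH]2)nc1-c1ccccc1` differs from compound 3 by a group of 3 heavy atoms (1 carbon, 1 nitrogen, 1 oxygen; no ring) in place of a group of 4 heavy atoms (1 carbon, 2 nitrogen, 1 sulfur; no ring), on a nitrogen on an aromatic ring with carbamoyl entering on a nitrogen on an aromatic ring. Within the data shown here, no measured compound carries carbamoyl, so the guide is the size of the other swaps at this part of the molecule. These stayed modest or smaller (a 2.3-fold higher number from compound 1 to compound 2 (0.36 log units; beyond the scatter)) and (a 2.2-fold lower number from compound 2 to compound 3 (0.34 log units; beyond the scatter)). The expectation in this assay is therefore no step beyond the scatter, with a slight lean towards a higher number. The expected step is small (a 1.3-fold higher number from compound 3 to compound 4 (0.13 log units; within the scatter)). Compound 4 is estimated at 4.5 nM (expected range 2 nM to 11 nM).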

Compound 4, half-maximal inhibitory concentration: 3.37 nM
Compound 4: middle estimate off by 1.3-fold (0.13 log units), on the high side, and the stated range covers the measured number.
By their numbers in this assay, from the lowest: compounds 1, 3 and 4 (each within the scatter of the next); then compound 2.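

In this assay, carbamoyl on this nitrogen in place of the sulfur-bearing group gives (no change at the digits printed from compound 3 to compound 4 (within the scatter)), so for this pair the sulfur is not needed to keep the number low. Carbamoyl also stands apart from ethyl on the same nitrogen (a 2.2-fold lower number from compound 2 to compound 4 (0.34 log units; beyond the scatter)), while ureido in place of chloro on the aromatic carbon gives (a 1.1-fold higher number from compound 1 to compound 4 (0.02 log units; within the scatter)), so compound 2 alone stands apart among these four. No measurement shown here accounts for these results.

Going by these compounds, whether a plain amino group or a longer chain such as butyl on this aromatic carbon would match compound 4 remains open.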